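The source may report more compounds than this note shows. Statements on the series, on what has been measured and on what is new or still open speak of the compounds shown alone.

Measured compounds in a functional assay on MDA-MB-231 cells (Homo sapiens) for antiproliferative activity, read by sulforhodamine B assay, with a stated time of 48 h; a lower number here means a stronger inhibitor, a higher number a weaker inhibitor:
- compound 1 `COc1cc(C(=O)/C=C\Nc2ccc(-c3nc4cc(OC)c(OC)c(OC)c4s3)cc2C)cc(OC)c1OC`: 12900 nM
- compound 2 `COc1ccc(C(=O)/C=C\Nc2ccc(-c3nc4cc(OC)c(OC)c(OC)c4s3)cc2C)cc1O`: 12400 nM
- compound 3 `COc1ccc(C(=O)/C=C\Nc2ccc(-c3nc4cc(OC)c(OC)c(OC)c4s3)cc2C)cc1F`: 2900 nM

Compound 1 has the highest number of the three. Compound 2 sits within the scatter of it, a 1.0-fold lower number from compound 1 to compound 2 (0.02 log units; within the scatter). Within the data shown here, compound 3 is the only measured compound that separates from it, a 4.4-fold lower number from compound 1 to compound 3 (0.65 log units; beyond the scatter), and from compound 2 the move to compound 3 is of the same size, a 4.3-fold lower number from compound 2 to compound 3 (0.63 log units; beyond the scatter). Every measured step thus changes the aryl ring on the carbonyl carbon, while the shared core of compound 1 and the ring carrying the methyl stay fixed.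

Compound 4 `COc1cc(C(=O)/C=C\Nc2ccc(-c3nc4cc(OC)c(OC)c(OC)c4s3)cc2)cc(OC)c1OC` is not yet measured. It differs from compound 1 by hydrogen in place of methyl on an aromatic carbon, on an aromatic carbon of a six-membered aromatic ring of carbon only, ortho to a large group and meta to a large group. Among the measured compounds shown here, no measured step touches this position, so none bears on it directly; the measured steps only show that the series responds to changes on the carbonyl-side ring, and nothing shows how it responds here. For the measured compounds named here, with no comparable step in hand, the expectation for this assay is no step beyond the scatter, a 1.1-fold lower number from compound 1 to compound 4 (0.03 log units; within the scatter), with a wide range to reflect the lack of a precedent. Compound 4 is therefore estimated at 12000 nM, between 4000 nM and 36000 nM.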

Compound 4, half-maximal inhibitory concentration: 16500 nM
Beside the measured number, compound 4's estimate is 1.4-fold (0.14 log units) below it; the measured number falls inside the stated range.
By their numbers in this assay, from the lowest: compound 3; then compounds 2, 1 and 4 (each within the scatter of the next).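

In this assay, among these compounds, hydrogen in place of methyl on an aromatic carbon is the first measured change away from the ring on the carbonyl carbon, and it gives a 1.3-fold higher number from compound 1 to compound 4 (0.11 log units; within the scatter). With the 3,4,5-trimethoxyphenyl group held fixed, this single pair shows that the methyl, ortho to a large group and meta to a large group, can be removed without a step beyond the scatter, so the number seen for compound 1 does not depend measurably on that methyl. No supporting measurement bears on why this step stays so small.

Among the compounds shown here, still open is whether hydrogen in place of methyl reads the same when a 3-fluoro-4-methoxyphenyl group sits on the carbonyl carbon, as in compound 3, the only compound here that separates from the others, for the present step was read only with the 3,4,5-trimethoxyphenyl group. Also open, on these data alone, is how this position answers to a group other than methyl or hydrogen, such as a chlorine atom, a methoxy group or an amine.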